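This account rests on a few compounds, and the source may have more. Where it says the series, first, only, none or still open, it means among the compounds named here.

All four compounds share one core: a piperidine whose nitrogen carries a propylsulfonyl group, with a morpholine amide and an aminomethyl arm on the same carbon; they differ only in the aromatic amide attached to that arm. In an assay on isolated protein for inhibition of sodium- and chloride-dependent glycine transporter 1 (Mus musculus) (on this read-out higher numbers stand for weaker inhibition and lower numbers for stronger inhibition), compound 1 `CCCS(=O)(=O)N1CCC(CNC(=O)c2c(F)ccc(Cl)c2F)(C(=O)N2CCOCC2)CC1` gives 42.8 nM. Compound 2 `CCCS(=O)(=O)N1CCC(CNC(=O)c2ccc(F)cc2C(F)(F)F)(C(=O)N2CCOCC2)CC1` carries a different substituted ring, and for compound 2 this assay reports "not determined" (no result reported). Compound 3 `CCCS(=O)(=O)N1CCC(CNC(=O)c2ccccc2OC(F)(F)F)(C(=O)N2CCOCC2)CC1` has a trifluoromethoxy group on its ring, and for compound 3 this assay likewise reports "not determined" (no result reported). So compound 3 stands without a number, as does compound 2, and only compound 1 anchors the series with a measured value.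

Compound 4 `CCCS(=O)(=O)N1CCC(CNC(=O)c2ccccc2Cl)(C(=O)N2CCOCC2)CC1` follows from compound 3 by one change: chloro in place of trifluoromethoxy on an aromatic carbon. Among the measured compounds shown here, no measured pair in this set shows the effect of this change, so the size and direction of the step in this assay cannot be read from the data; a modest shift in either direction, or none beyond the scatter, is all that can be expected. Taking compound 1 as the only anchor, compound 4 is estimated at 90 nM, with a plausible range from 20 nM to 400 nM.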

Compound 4, half-maximal inhibitory concentration in the sodium- and chloride-dependent glycine transporter 1 assay: 95.3 nM
Compound 4: middle estimate off by 1.1-fold (0.02 log units), on the low side; measured number inside the range.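

In the sodium- and chloride-dependent glycine transporter 1 assay the series gains a second number, and 2-chlorophenyl in place of 3-chloro-2,6-difluorophenyl gives a 2.2-fold higher number from compound 1 to compound 4 (0.35 log units; beyond the scatter) so inhibition weakens modestly but remains measurable on a ring with a single chloro group. In a physicochemical assay for solubility (a lower number here means a less soluble compound, a higher number a more soluble compound), compound 3 gives 10000 ug/mL and compound 4 gives 10000 ug/mL so the printed values are the same with trifluoromethoxy and with chloro on this aromatic carbon. Neither compound 2 nor compound 3 has a number in the sodium- and chloride-dependent glycine transporter 1 assay so steps to or from them there cannot be read.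

No measured property is available here to explain these results. Also open, on these data alone, is how the sodium- and chloride-dependent glycine transporter 1 assay would respond to an amine, a carboxylic acid or a methoxy group on this ring.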